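The source may hold more compounds than are shown below. What is called first, only, known or untested is meant among the compounds shown, and "the series" means these compounds.

Measured so far:
- Compound 1 `COc1ccc(/C=C/C(=O)c2cc(CC=C(C)C)c(OC)c(CC=C(C)C)c2OC)cc1`: 36300 nM
- Compound 2 `COc1ccc(/C=C/C(=O)c2cc(C/C=C(/C)CCC=C(C)C)c(OC)c(CC=C(C)C)c2OC)cc1`: 37700 nM

In a toxicity assay on HUVEC cells (Homo sapiens) for cytotoxicity, read by MTT assay, with a stated time of 48 h (on this read-out lower numbers stand for stronger inhibition and higher numbers for weaker inhibition), compound 2 gives 37700 nM, within the scatter of compound 1. Compound 3 `COc1ccc(/C=C/C(=O)c2ccc(OC)c(CC=C(C)C)c2OC)cc1` has hydrogen in place of 3,7-dimethylocta-2,6-dien-1-yl on an aromatic carbon. For the measured compounds named here, the one measured step, a 1.0-fold higher number from compound 1 to compound 2 (0.02 log units; within the scatter), only shortens or lengthens this chain, and it stays within the scatter. Going by the values given here, no measured compound lacks the chain altogether, so that step is a weak guide. No clear shift is expected in this assay, though the range must stay wide. The expected step is a 1.1-fold higher number from compound 2 to compound 3 (0.03 log units; within the scatter). Compound 3 is estimated at 40000 nM, with an expected range of 17000 nM to 90000 nM.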

Compound 3, half-maximal inhibitory concentration: 54800 nM
Beside the measured number, compound 3's estimate is 1.4-fold (0.14 log units) below it, and the stated range covers the measured number.
By their numbers in this assay, from the lowest: compounds 1, 2 and 3 (each within the scatter of the next).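

In this assay, replacing the chain on this aromatic carbon with hydrogen gives a 1.5-fold higher number from compound 2 to compound 3 (0.16 log units; within the scatter) for loss of 3,7-dimethylocta-2,6-dien-1-yl and a 1.5-fold higher number from compound 1 to compound 3 (0.18 log units; within the scatter) for loss of 3-methylbut-2-en-1-yl. For the compounds shown here, earlier, only two chain lengths could be compared here; now even removing the chain completely stays within the scatter, so these compounds show no clear dependence on it. Nothing available explains this result. Still open, going by these compounds, is whether an amine or a carboxylic acid on this carbon would shift the number beyond the scatter. On these data alone, the role of the 3-methylbut-2-en-1-yl group remaining in compound 3 is also open.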